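A few compounds are considered here, and "the series" means these few. Any claim that something is new, unique, unknown or untested is made for them only; others in the source may bear on it.

Of the compounds shown here, two have been tested so far in a functional assay on the whole organism for agonist activity, with Mus musculus as the target; a higher number here means that more compound is needed for the effect, a lower number that less compound is needed. Going by the values given here, compound 2 `CN1CCN(CC#CCn2ccnc2)C1=O` gives 0.97 mg/kg, the only actual number available, which makes it the single firm reference point. Compound 1 `Cc1cncn1CC#CCN1CCNC1=O` gives only a limit of the assay, > 100 mg/kg. Compound 3 `Cc1cncn1CC#CCN1CCN(C)C1=O` is compound 2 with one change, methyl in place of hydrogen on an aromatic carbon. Among the compounds with values here, no pair of measured compounds isolates this change, so its size cannot be read directly. The only hint is that, while differing from compound 2 elsewhere too, compound 1 carries the same methyl and stops at the limit > 100 mg/kg. A loss of potency beyond the scatter therefore seems likelier than a gain. The expected step is an 8.2-fold higher number from compound 2 to compound 3 (0.92 log units; beyond the scatter), meaning that more compound would be needed. Compound 3 is estimated at 8 mg/kg, with an expected range from 1.5 mg/kg to 60 mg/kg.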

Compound 3, dose for half-maximal effect: 2.5 mg/kg
Beside the measured number, compound 3's estimate is 3.2-fold (0.51 log units) above it; the measured number falls inside the stated range.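

Methyl in place of hydrogen on an aromatic carbon, next to the ring nitrogen, now has a measured size in this assay: a 2.6-fold higher number from compound 2 to compound 3 (0.41 log units; beyond the scatter), so more compound is needed, but the effect is kept at a modest cost. Methyl in place of hydrogen on an amide-type nitrogen in a ring goes with a much larger difference, an at least 40-fold lower number from compound 1 to compound 3 (1.60 log units; beyond the scatter), so among these compounds the methyl on that nitrogen counts for far more than the one on the aromatic carbon. The size of that larger step is open-ended, as compound 1 gives a limit and not a number: the limit of > 100 mg/kg in this assay, at which 1 of the 3 values shown sits.

As far as these compounds go, how ethyl or a chlorine atom on this aromatic carbon would compare with methyl stays open. So does the outcome of a longer chain on the amide-type nitrogen.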